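Swapping an Amide Amine for Morpholine: Solubility Outlook

The source may hold more compounds than are shown below. What is called first, only, known or untested is meant among the compounds shown, and "the series" means these compounds.

Compound 1 `CCOc1cc(NC(=O)C2(NC(=O)c3ccc4c(C5CCCC5)c(-c5ncc(Cl)cn5)n(C)c4c3)CCC2)ccc1/C=C/C(=O)OCCOCCOC` gives in an ADME assay for solubility (a lower number here means a less soluble compound, a higher number a more soluble compound), only a limit of the assay, < 30000 ug/mL.
Compound 2 `CCOc1cc(NC(=O)C2(NC(=O)c3ccc4c(C5CCCC5)c(-c5ncc(Cl)cn5)n(C)c4c3)CCC2)ccc1/C=C/C(=O)OCC(=O)N(C)C(C)C` gives in this assay only a limit of the assay, < 200000 ug/mL.

Compound 2 thus stands at a limit rather than at a number; of the two values in hand, one sits at the limit of < 200000 ug/mL in this assay, at which 1 of the 2 values shown sits, and the other at the limit of < 30000 ug/mL in this assay, at which 1 of the 2 values shown sits. The step that the two limits leave unreadable from compound 1 to compound 2 is therefore unreadable: it exchanges a (2-methoxyethoxy)methyl group for an isopropyl(methyl)carbamoyl group on a saturated chain carbon bound to an oxygen next to a carbonyl group, and the two limits let no size be read. Compound 3 `CCOc1cc(NC(=O)C2(NC(=O)c3ccc4c(C5CCCC5)c(-c5ncc(Cl)cn5)n(C)c4c3)CCC2)ccc1/C=C/C(=O)OCC(=O)N1CCOCC1` differs from compound 2 by morpholin-4-yl in place of isopropyl(methyl)amino on a carbonyl carbon, a change on a carbonyl carbon whose other neighbour is a saturated chain carbon. Only the unreadable step bears on this change, so no direction or size beyond the scatter can be drawn from the measured compounds. The expectation is a step that the limit leaves unreadable from compound 2 to compound 3, read as no change beyond the scatter. Compound 3 is estimated at 100000 ug/mL, with a range from 20000 ug/mL to 200000 ug/mL, and most probably the assay again reports only a limit.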

Compound 3, solubility: < 30000 ug/mL
Compound 3 gave a limit, no number; the forecaster's own chance of this, stated with the estimate: 70%; at least 3.3-fold (0.52 log units) between middle value and limit.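

In this assay compound 3 again gives only a limit of the assay, < 30000 ug/mL. Among the compounds shown here, since compound 1, compound 2 and compound 3 all stand at limits, no step among them can be read. Going by these compounds, the actual solubility of each compound stays open, as does whether morpholin-4-yl in place of isopropyl(methyl)amino changes it at all.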